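The compounds below may be only part of what the source reports. "The series", "measured", "known", "first", "only" and "open" are said of these compounds alone.

Measured compounds:
compound 1 `COC(C(=O)OC(C)Cn1cnc2c1c(=O)n(C)c(=O)n2C)c1cccc2ccccc12` with 34.6%
compound 2 `COC(C(=O)OC(C)Cn1cnc2c1c(=O)n(C)c(=O)n2C)c1ccc2ccccc2c1` with 15%

Both were tested in a functional assay on CCRF-CEM cells (Homo sapiens) for antiproliferative activity, read by MTT assay, with a stated time of 72 h, tested at 200 uM; on this read-out higher numbers stand for a weaker effect at the one concentration tested and lower numbers for a stronger effect. For the measured compounds named here, on those two numbers compound 2 stands lowest, and the only step recorded, a number 19.6 percentage points lower from compound 1 to compound 2 (beyond the scatter), separates it from compound 1 by more than the usual scatter.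

Compound 3 `COC(C(=O)OC(C)Cn1cnc2c1c(=O)n(C)c(=O)n2C)c1ccc(C(C)(C)C)cc1` is not yet measured. It differs from compound 2 in one place: 4-(tert-butyl)phenyl in place of naphthalen-2-yl on a saturated chain carbon bound to a carbonyl carbon and an oxygen on a saturated carbon.

Going by the values given here, no measured step bears directly on this change; the one step recorded, a number 19.6 percentage points lower from compound 1 to compound 2 (beyond the scatter), concerns only an exchange of one naphthyl for the other, and it was modest. The estimate for compound 3 therefore rests on little: a step of a number 10 percentage points higher from compound 2 to compound 3 (within the scatter) is expected, leaning toward a higher number than compound 2 but with wide uncertainty. Compound 3 is expected to give about 25%, somewhere between 8% and 45%.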

Compound 3, a percentage reported as activity, at one concentration (the size of the read-out at that concentration, not a potency): 0%
Beside the measured number, compound 3's estimate is 25 percentage points above it, outside the stated range (below it).
By their numbers in this assay, from the lowest: compound 3; then compound 2; then compound 1.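

In this assay, this position on the saturated chain carbon does not depend on a naphthyl group for a low number: 4-(tert-butyl)phenyl in place of naphthalen-2-yl gives a number 15 percentage points lower from compound 2 to compound 3 (beyond the scatter) and in place of naphthalen-1-yl gives a number 34.6 percentage points lower from compound 1 to compound 3 (beyond the scatter) as its step. Both steps are printed as beyond the scatter, so compound 3 stands lowest of the three, with one six-membered aromatic ring where each naphthyl group has two, at the same count of 10 heavy atoms. Nothing available accounts for this shift.

On these data alone, whether a phenyl ring carrying a carboxylic acid, an amine or an unbranched butyl chain in place of tert-butyl would keep the number of compound 3 stays open. With one concentration tested, the read-out tells only of a stronger or weaker effect at that concentration for all three compounds.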